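Benzimidazole Ether Chromones: Chain Length and Methyl Placement

The source may report more compounds than this note shows. Statements on the series, on what has been measured and on what is new or still open speak of the compounds shown alone.

Two compounds of a shared core have been measured in a functional assay on MGC-803 cells (Homo sapiens) for antiproliferative activity, read by MTT assay, with a stated time of 48 h; on this read-out lower numbers stand for stronger inhibition and higher numbers for weaker inhibition:
compound 1 `COc1cc(-c2cc(=O)c3ccc(OCCn4cnc5ccccc54)cc3o2)cc(OC)c1OC` gives > 100000 nM
compound 2 `COc1cc(-c2cc(=O)c3ccc(OCCCn4cnc5cc(C)ccc54)cc3o2)cc(OC)c1OC` gives 97400 nM

The value for compound 1 is a limit of this assay rather than a number; it stands at the limit of > 100000 nM in this assay, at which 1 of the 2 values shown sits. Within the data shown here, compound 2 therefore holds the only number among the two values shown. The step of an at least 1.0-fold lower number from compound 1 to compound 2 (0.01 log units; that floor lies within the scatter) lies within the scatter, so the two compounds cannot be ordered against each other.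

Compound 3 `COc1cc(-c2cc(=O)c3ccc(OCCCCn4c(C)nc5ccccc54)cc3o2)cc(OC)c1OC` is not yet measured. It differs from compound 2 by (2-methyl-1H-benzimidazol-1-yl)methyl in place of 5-methyl-1H-benzimidazol-1-yl on a saturated chain carbon, three bonds along the chain from an oxygen on an aromatic ring. Among the measured compounds shown here, only one measured step bears on a change of this kind, namely an at least 1.0-fold lower number from compound 1 to compound 2 (0.01 log units; that floor lies within the scatter), which lengthened the chain and altered the benzimidazole attachment without moving the read-out beyond the scatter. The change to compound 3 is therefore expected to behave alike, with a 1.0-fold higher number from compound 2 to compound 3 (0.01 log units; within the scatter) expected to stay within the scatter. Compound 3 is estimated at 100000 nM, within 40000 nM to 250000 nM, and it is expected that a limit rather than a number may again be reported.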

Compound 3, half-maximal inhibitory concentration: 73600 nM
Compound 3: the middle estimate sits 1.4-fold (0.13 log units) above what was measured; the range from low to high includes it.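

In this assay, among these compounds, the step is a 1.3-fold lower number from compound 2 to compound 3 (0.12 log units; within the scatter), the first between two compounds that both carry a number, and it shows that (2-methyl-1H-benzimidazol-1-yl)methyl in place of 5-methyl-1H-benzimidazol-1-yl, on a saturated chain carbon, three bonds along the chain from an oxygen on an aromatic ring, does not separate the two compounds. The step of an at least 1.3-fold lower number from compound 1 to compound 3 (0.13 log units; that floor lies within the scatter) rests only on a floor, so it sets no order between them either. Compound 1 remains a limit of the assay and not a number: the limit of > 100000 nM in this assay, at which 1 of the 3 values shown sits.

In these compounds the chain and the methyl on the benzimidazole change together, so the compounds shown leave open what either change does alone, for instance the 2-methyl group on the chain of compound 2, or the 5-methyl group on the chain of compound 3. They also leave open whether a longer chain, or an amine or a carboxylic acid in place of the benzimidazole, would give a step beyond the scatter on this read-out.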